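Fluorine repeated on the benzyl ring of a rhodanine-free core

The compounds below may be only part of what the source reports. "The series", "measured", "known", "first", "only" and "open" are said of these compounds alone.

Going by the values given here, compound 1 `O=C(O)CN1C(=O)/C(=C/c2nc3ccccc3n2Cc2ccc(Br)cc2)SC1=S` is the only member of this small set with a numerical result: in a functional assay on HeLa cells (Homo sapiens) for cytotoxicity, read by MTT assay, with a stated time of 48 h (a lower number here means a stronger inhibitor, a higher number a weaker inhibitor), compound 1 gives 12900 nM. Compound 2 `O=C(O)CN1C(=O)/C(=C/c2nc3ccccc3n2Cc2ccc(Br)cc2F)SC1=S` carries one change relative to compound 1, (fluoro in place of hydrogen on an aromatic carbon). In this assay compound 2 reaches only a limit of the assay, > 50000 nM. The step is an at least 3.8-fold higher number from compound 1 to compound 2 (0.58 log units; beyond the scatter). Compound 3 `O=C(O)CN1C(=O)/C(=C/c2nc3ccccc3n2Cc2cccc(F)c2)SC1=S` differs from compound 1 in its core, (3-fluorophenyl in place of 4-bromophenyl on a saturated chain carbon bound to an aromatic nitrogen). In this assay compound 3 likewise stops at a limit, > 50000 nM. That step is an at least 3.8-fold higher number from compound 1 to compound 3 (0.58 log units; beyond the scatter). Because both compound 2 and compound 3 sit at the limit of > 50000 nM in this assay, at which 2 of the 3 values shown sit, the pair shows a step that the two limits leave unreadable from compound 2 to compound 3.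

Compound 4 `O=C(O)CN1C(=O)/C(=C/c2nc3ccccc3n2Cc2ccc(F)c(F)c2)SC1=S` has not yet been measured in this assay. Relative to compound 3 it carries fluoro in place of hydrogen on an aromatic carbon, the same kind of change as the one made from compound 1 to compound 2, though the surroundings differ: in compound 2 the new fluoro stands ortho to a large group and meta to a bromo group, whereas in compound 4 it stands ortho to a fluoro group and para to a large group. The earlier instance gave an at least 3.8-fold higher number from compound 1 to compound 2 (0.58 log units; beyond the scatter), and compound 3 already rests at a limit, > 50000 nM, so the expected step is a step that the limit leaves unreadable from compound 3 to compound 4. Compound 4 is therefore estimated at 70000 nM in this assay, most likely reported only as a limit, within 20000 nM to 250000 nM.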

Compound 4, half-maximal inhibitory concentration: 16000 nM
Estimate against measurement, compound 4: 4.4-fold (0.64 log units) above, outside the stated range (below it).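

In this assay, the same fluoro in place of hydrogen on an aromatic carbon did not carry over from one core to the other, and its two instances ran in opposite directions: the same change on two cores in this assay, an at least 3.8-fold higher number (0.58 log units; beyond the scatter) from compound 1 to compound 2 and an at least 3.1-fold lower number (0.49 log units; beyond the scatter) from compound 3 to compound 4, at least 12-fold (1.08 log units) apart, beyond the scatter of two such steps

The new instance is an at least 3.1-fold lower number from compound 3 to compound 4 (0.49 log units; beyond the scatter); the other step to a limited compound is an at least 3.1-fold lower number from compound 2 to compound 4 (0.49 log units; beyond the scatter), and the comparison with the one earlier numerical result is a 1.2-fold higher number from compound 1 to compound 4 (0.09 log units; within the scatter). This shows that the outcome of the change in this series depends on the compound that receives it, but the two steps give only bounds on their sizes, and two instances neither give a rule for other members of the series nor show why the direction differs: the limit of > 50000 nM in this assay, at which 2 of the 4 values shown sit.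

The compounds shown leave open whether a chloro, methyl or methoxy group in place of the added fluoro would follow the 3-fluorobenzyl to 3,4-difluorobenzyl step. They also leave open how that step would read if the carboxylic acid of the shared core were replaced by an amide, or if the chain bearing it were longer.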